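A few compounds are considered here, and "the series" means these few. Any claim that something is new, unique, unknown or untested is made for them only; others in the source may bear on it.

Of the compounds shown here, three share the same core and have been measured in an assay (Equus caballus) for inhibition of Thromboxane-A synthase (Homo sapiens), using microsomes; on this read-out lower numbers stand for stronger inhibition and higher numbers for weaker inhibition. Compound 1, `CC(C)(O)C(CCC/C=C(\c1ccccc1)c1cccnc1)C(=O)O`, gives 42 nM, the lowest of the three numbers. Compound 2, `O=C(O)CCCC/C=C\c1cccnc1`, gives 250 nM. Compound 3, `CCOC(=O)CCCC/C=C(\c1ccccc1)c1cccnc1`, gives 600 nM. Between compound 1 and compound 3 there is a single change, (ethoxycarbonyl)methyl in place of 1-carboxy-2-hydroxy-2-methylpropyl on a saturated chain carbon, three bonds along the chain from a double-bonded chain carbon, and this change brings a 14-fold higher number from compound 1 to compound 3 (1.15 log units; beyond the scatter).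

Compound 4, `O=C(O)C(CCC/C=C(\c1ccccc1)c1cccnc1)Sc1ccccc1`, has not been measured. Compared with compound 1 it carries phenylsulfanyl in place of 1-hydroxy-1-methylethyl on a saturated chain carbon bound to a carbonyl carbon and a saturated chain carbon. Among the measured compounds shown here, no measured step isolates this change; the only step that touches the same part of the chain is the large one from compound 1 to compound 3, which alters both the carboxyl side and the group carrying the hydroxyl at once. The loss of the hydroxyl group, the only hydrogen-bond donor of the side group, is therefore untested, so the expectation for compound 4 is a moderate rise, a 2.6-fold higher number from compound 1 to compound 4 (0.42 log units; beyond the scatter), with wide uncertainty. Compound 4 is thus estimated at 110 nM, within a range from 25 nM to 450 nM.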

Compound 4, half-maximal inhibitory concentration: 33 nM
Compound 4: the middle estimate sits 3.3-fold (0.52 log units) above what was measured; the range from low to high includes it.
By their numbers in this assay, from the lowest: compounds 4 and 1 (each within the scatter of the next); then compound 2; then compound 3.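

In this assay, phenylsulfanyl in place of 1-hydroxy-1-methylethyl on this saturated chain carbon brings a 1.3-fold lower number from compound 1 to compound 4 (0.10 log units; within the scatter), so the two compounds read alike. This position therefore tolerates a swap from a hydroxyl-bearing group to a larger group with a six-membered aromatic ring and no hydrogen-bond donor, so the hydroxyl is not needed to keep the number at this level in this series. Nothing available explains why two such different groups give matching numbers.

Still open, on these data alone, is how far this tolerance extends, for instance whether an amine or a plain methyl on the same carbon would read alike. A phenoxy group, with oxygen in place of sulfur, would show whether the sulfur atom itself matters.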